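From compound 3 to compound 4: amide side chain

The source may report more compounds than this note shows. Statements on the series, on what has been measured and on what is new or still open speak of the compounds shown alone.

Measured in a functional assay on PC-3 cells (Homo sapiens) for antiproliferative activity, read by MTT assay, with a stated time of 48 h; a higher number here means a weaker inhibitor, a lower number a stronger inhibitor:
compound 1 `CCOc1ccc(NC(=O)c2ccc(C(CC)(CC)c3ccc(OCCC(O)(CC)CC)c(C)c3)n2CC)cc1` gives > 50000 nM (a limit)
compound 2 `CCC(C)C(NC(=O)c1ccc(C(CC)(CC)c2ccc(OCCC(O)(CC)CC)c(C)c2)n1CC)C(=O)OC` gives > 50000 nM (a limit)
compound 3 `CCn1c(C(=O)NC(CC(=O)O)C(=O)OC)ccc1C(CC)(CC)c1ccc(OCCC(O)(CC)CC)c(C)c1` gives 11200 nM (a number)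

Only compound 3 has a number. Compound 1 and compound 2 stand at the limit of > 50000 nM in this assay, at which 2 of the 3 values shown sit, here.

Compound 4 `CCn1c(C(=O)NC(C)C(=O)O)ccc1C(CC)(CC)c1ccc(OCCC(O)(CC)CC)c(C)c1` carries a group of 5 heavy atoms (3 carbon, 2 oxygen; no ring) in place of a group of 9 heavy atoms (5 carbon, 4 oxygen; no ring), on an amide-type nitrogen, with 1-carboxyethyl as the entering group.

Among the compounds with values here, two measured steps bear on this: an at least 4.4-fold lower number from compound 1 to compound 3 (0.64 log units; beyond the scatter) and an at least 4.4-fold lower number from compound 2 to compound 3 (0.64 log units; beyond the scatter). Both are open-ended, and neither tests 1-carboxyethyl. Carboxymethyl in compound 3 and 1-carboxyethyl in compound 4 both hold a carboxy group, so compound 4 is expected to stay close to compound 3 at 11200 nM in this series.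

No step beyond the scatter is expected in this assay, the expected step being a 1.3-fold higher number from compound 3 to compound 4 (0.13 log units; within the scatter) in size.

For compound 4 the estimated value is 15000 nM, with an expected range of 5000 nM to 50000 nM.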

Compound 4, half-maximal inhibitory concentration: 11700 nM
Compound 4: the middle estimate sits 1.3-fold (0.11 log units) above what was measured, and the stated range covers the measured number.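

In this assay, the group on the amide-type nitrogen shrinks to 1-carboxyethyl with no loss, a 1.0-fold higher number from compound 3 to compound 4 (0.02 log units; within the scatter), so the larger group of compound 3 offers nothing measurable over it. Against the groups without a carboxy group, the gain holds: an at least 4.2-fold lower number from compound 2 to compound 4 (0.63 log units; beyond the scatter), and an at least 4.2-fold lower number from compound 1 to compound 4 (0.63 log units; beyond the scatter). Both of these steps are open-ended, since compound 1 and compound 2 each stand at a limit: the limit of > 50000 nM in this assay, at which 2 of the 4 values shown sit.

On these data alone, whether the carboxy group itself is required remains open, and a primary amide or an amine on the same chain carbon would test it. Any level well beyond these values also remains unknown for this side chain.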